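The source may hold more compounds than are shown below. What is called first, only, known or untested is meant among the compounds shown, and "the series" means these compounds.

Working notes on the series. Compound 1 `N#Cc1cccc(S(=O)(=O)c2ccc3c(c2)CCC[C@H]3C=N)c1`, compound 2 `NC[C@@H]1CCCc2cc(S(=O)(=O)c3cc(F)cc4[nH]cnc34)ccc21` and compound 3 `O=C(NC[C@@H]1CCCc2cc(S(=O)(=O)c3cccc(F)c3)ccc21)c1ncc[nH]1` share one core. In an assay on isolated protein for displacement of a labelled ligand from 5-hydroxytryptamine receptor 6 (Homo sapiens) (a higher number here means a weaker inhibitor, a lower number a stronger inhibitor), compound 1 gives 0.501 nM, compound 2 gives 5.01 nM, and compound 3 gives 15.9 nM, the highest of the three numbers and beyond the scatter from both others. Compound 4 `COCCNC[C@@H]1CCCc2cc(S(=O)(=O)c3cccc(F)c3)ccc21` is not yet measured; it differs from compound 3 by 2-methoxyethyl in place of (1H-imidazol-2-yl)carbonyl on an amine nitrogen. Among the measured compounds shown here, no pair of measured compounds isolates this change. Compound 2 carries an unsubstituted amine on the same chain and sits lower than compound 3 in this assay. A downward step of moderate size is therefore expected for compound 4, a 2.7-fold lower number from compound 3 to compound 4 (0.42 log units; beyond the scatter). The estimate for compound 4 in this assay is 6 nM, between 2 nM and 20 nM.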

Compound 4, inhibition constant: 0.251 nM
Beside the measured number, compound 4's estimate is 24-fold (1.38 log units) above it; measured number below the stated range.
By their numbers in this assay, from the lowest: compounds 4 and 1 (each within the scatter of the next); then compound 2; then compound 3.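

Among the compounds shown here, on the amine nitrogen whose other neighbour is a saturated chain carbon, 2-methoxyethyl in place of (1H-imidazol-2-yl)carbonyl gives a 63-fold lower number from compound 3 to compound 4 (1.80 log units; beyond the scatter) in this assay, the first step that isolates a change at this place. This place therefore accepts an open chain with no ring and no carbonyl, with compound 4 at 0.251 nM. Nothing available explains the size of this step. Which part of the change carries the step stays open: a propyl chain or an acetyl group on the same nitrogen would separate the ether oxygen, the carbonyl and the ring.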